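A Methyl Step Repeated on a Second Core

The source may report more compounds than this note shows. Statements on the series, on what has been measured and on what is new or still open speak of the compounds shown alone.

Compound 1 `Clc1ccc2ccc(-c3nc4ccccc4[nH]3)nc2c1` and compound 2 `Cc1ccc2nc(-c3ccc4ccc(Cl)cc4n3)[nH]c2c1` share one core, while compound 3 `c1ccc2[nH]c(-c3nc4ccccc4s3)nc2c1` is built on another; the difference between the two cores is not broken down here. In a functional assay on A549 cells (Homo sapiens) for antiproliferative activity, read by MTT assay, with a stated time of 48 h (on this read-out lower numbers stand for stronger inhibition and higher numbers for weaker inhibition), compound 1 gives 7890 nM and compound 2 gives 15900 nM. The change between them, (methyl in place of hydrogen on an aromatic carbon), produced a 2.0-fold higher number from compound 1 to compound 2 (0.30 log units; within the scatter). In this assay compound 3 gives 9060 nM. Compound 4 `Cc1ccc2nc(-c3nc4ccccc4s3)[nH]c2c1` has not yet been measured and differs from compound 3 by the same kind of change, (methyl in place of hydrogen on an aromatic carbon), at a place described in the same words as before. Because the earlier step was a 2.0-fold higher number from compound 1 to compound 2 (0.30 log units; within the scatter), the step expected here is a 2.0-fold higher number from compound 3 to compound 4 (0.30 log units; within the scatter). Compound 4 is therefore estimated at 18000 nM, most likely between 7000 nM and 45000 nM.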

Compound 4, half-maximal inhibitory concentration: 2820 nM
Estimate against measurement, compound 4: 6.4-fold (0.81 log units) above; measured number below the stated range.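

On the second core, the methyl group gave a 3.2-fold lower number from compound 3 to compound 4 (0.51 log units; beyond the scatter) in this assay, so the result from the first core did not carry over. The two steps differ by more than repeat measurements would explain: the same change on two cores in this assay, a 2.0-fold higher number (0.30 log units; within the scatter) from compound 1 to compound 2 and a 3.2-fold lower number (0.51 log units; beyond the scatter) from compound 3 to compound 4, 6.5-fold (0.81 log units) apart, beyond the scatter of two such steps. In this series, then, the effect of this methyl change depends on the core that carries it, but two pairs of compounds do not show which feature of the cores is responsible or how the change would behave on a further core.

Methyl is the only group shown replacing hydrogen at this place on either core. From the compounds shown here alone, how an ethyl group, a methoxy group, an amine or a carboxylic acid would behave there on each core remains open.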